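The compounds below may be only part of what the source reports. "The series", "measured", "known", "first", "only" and "open" are said of these compounds alone.

In a functional assay on HCT-116 cells (Homo sapiens) for inhibition, read by CCK-8 assay, with a stated time of 72 h, tested at 2 uM (a lower number here means less inhibition of growth, a higher number more inhibition of growth at the concentration tested), compound 1 (`Nc1ccccc1NC(=O)/C=C/c1ccc(CSc2cccc(F)c2)cc1`) gives 7.95% and lies within the scatter of compound 3 (`Nc1ccccc1NC(=O)c1ccc(CSc2cccc(F)c2)cc1`) at 5.5% while compound 2 (`CCc1ccc(SCc2ccc(C(=O)Nc3ccccc3N)cc2)cc1`) stands clearly higher at 40.7% in the same test. Compound 4 (`Nc1ccccc1NC(=O)/C=C/c1ccc(CSc2cccc3ccccc23)cc1`) changes one group of compound 1 (naphthalen-1-yl in place of 3-fluorophenyl on a sulfur) with naphthalen-1-yl in place of 3-fluorophenyl on a sulfur. For the measured compounds named here, the only measured step at such a sulfur is large (a number 35.2 percentage points lower from compound 2 to compound 3 (beyond the scatter)), and there 4-ethylphenyl gives way to 3-fluorophenyl, with a core that differs from that of compound 1. Read in reverse, it points upward on leaving 3-fluorophenyl, but no naphthalen-1-yl compound has been measured and the step may not carry over to the core of compound 1. A moderate upward move is expected (a number 14.1 percentage points higher from compound 1 to compound 4 (beyond the scatter)). Compound 4 is estimated at 22% (expected range 6% to 48%).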

Compound 4, percent growth inhibition at one concentration: 11%
Beside the measured number, compound 4's estimate is 11 percentage points above it; the range from low to high includes it.
By their numbers in this assay, from the lowest: compounds 3, 1 and 4 (each within the scatter of the next); then compound 2.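

On the core of compound 1, the change from 3-fluorophenyl to naphthalen-1-yl on a sulfur gives a number 3.1 percentage points higher from compound 1 to compound 4 (within the scatter) in this assay, so the second aromatic ring leaves no readable mark on growth inhibition here. This single step does not match the size of a number 35.2 percentage points lower from compound 2 to compound 3 (beyond the scatter), which belongs to a different core. No supporting data explain either step.

Open, on these data alone, is whether 4-ethylphenyl on the core of compound 1 would bring the number near compound 2 at 40.7% in the same test. Also open, as far as these compounds go, is how a longer chain or an amine on the sulfur would read.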